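The source may hold more compounds than are shown below. What is called first, only, known or untested is meant among the compounds shown, and "the series" means these compounds.

Measured so far:
- compound 1 `Cc1cc(C(=O)Nc2c(F)cccc2F)nn1Cc1cc(Cl)ccc1OCc1ccccc1`: 10 nM
- compound 2 `Cc1cc(NC(=O)CC(C)(C)C)nn1Cc1cc(Cl)ccc1OCc1ccccc1`: 10 nM

In an assay on CHO-K1 cells for displacement of a labelled ligand from prostaglandin E2 receptor EP1 subtype (Homo sapiens) (a higher number here means a weaker inhibitor, a lower number a stronger inhibitor), compound 2 stands level with compound 1; the step of no change at the digits printed from compound 1 to compound 2 (within the scatter) lies within the scatter. Compound 3 `Cc1cc(NC(=O)C2CCCO2)nn1Cc1cc(Cl)ccc1OCc1ccccc1` carries the change (oxolan-2-yl in place of neopentyl on a carbonyl carbon). Going by the values given here, no measured step touches the amide side chain beyond the one above, which only shows that the series tolerates a swap on that carbon without loss. A similar-sized replacement is therefore expected to move little, and compound 3 is estimated at 20 nM (range 5 nM to 80 nM), an expected step of a 2.0-fold higher number from compound 2 to compound 3 (0.30 log units; within the scatter) from compound 2.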

Compound 3, half-maximal inhibitory concentration: 39.8 nM
Compound 3: middle estimate off by 2.0-fold (0.30 log units), on the low side; the measured number falls inside the stated range.
By their numbers in this assay, from the lowest: compounds 1 and 2 (each within the scatter of the next); then compound 3.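

In this assay the side chain on the carbonyl carbon is not freely interchangeable: oxolan-2-yl in place of neopentyl gives a 4.0-fold higher number from compound 2 to compound 3 (0.60 log units; beyond the scatter) even though both groups count 5 heavy atoms. Against the (2,6-difluorophenyl)carbamoyl group, the ((oxolan-2-yl)carbonyl)amino group gives a 4.0-fold higher number from compound 1 to compound 3 (0.60 log units; beyond the scatter) and so does not share the level standing of the first two compounds. Nothing available explains this loss.

Going by these compounds, whether cyclopentyl, a ring with no oxygen, returns to the neopentyl level stays open. So does the effect of an amine or a carboxylic acid on that carbonyl carbon.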